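The source may report more compounds than this note shows. Statements on the series, on what has been measured and on what is new or still open speak of the compounds shown alone.

Compound 1 `CCOC(=O)/C(C)=C/C1=CC[C@H]2C(C)(C)CCC[C@]2(C)[C@H]1C=O`: 37000 nM
Compound 2 `CC1(C)CCC[C@]2(C)[C@@H](C=O)C(/C=C/C(=O)OCc3ccccc3)=CC[C@@H]12`: 39000 nM

In a functional assay on SK-MEL-28 cells (Homo sapiens) for inhibition, read by MTT assay, with a stated time of 72 h (a lower number here means a stronger inhibitor of growth, a higher number a weaker inhibitor of growth), compound 2 gives 39000 nM, and this number lies within the usual scatter of compound 1 at 37000 nM. Within the data shown here, with only two measured compounds, the picture of how these molecules behave is still thin.

Compound 3 `C#CCCCOC(=O)/C=C/C1=CC[C@H]2C(C)(C)CCC[C@]2(C)[C@H]1C=O` keeps the core of compound 2 but has but-3-yn-1-yl in place of phenyl on a saturated chain carbon bound to an oxygen next to a carbonyl group. Among the measured compounds shown here, no measured pair shows this change on its own, so the expectation rests on little. Compound 1 at 37000 nM and compound 2 at 39000 nM differ in structure yet sit within the scatter, so no step beyond the scatter is expected in this assay. The estimated change is a 1.3-fold lower number from compound 2 to compound 3 (0.11 log units; within the scatter). For compound 3 the expected value is 30000 nM, with an estimated range of 12000 nM to 70000 nM.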

Compound 3, concentration for 50% growth inhibition: 36000 nM
Beside the measured number, compound 3's estimate is 1.2-fold (0.08 log units) below it; the range from low to high includes it.
By their numbers in this assay, from the lowest: compounds 3, 1 and 2 (each within the scatter of the next).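

At the saturated chain carbon bound to an oxygen next to a carbonyl group, placing but-3-yn-1-yl where phenyl stood gives, in this assay, a 1.1-fold lower number from compound 2 to compound 3 (0.03 log units; within the scatter) and no more. This is the first pair shown that differs in one place only, and it shows that a six-membered aromatic ring can give way to a chain with no ring and a triple bond without a step beyond the scatter. Nothing measured here explains why these two groups read alike.

Still open, on these data alone, is whether a group of a different kind at this place, such as an amine, a carboxylic acid or a longer chain, would move the number beyond the scatter. As far as these compounds go, it is also open whether this swap would read the same way on cells other than those of this assay.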